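Pyridyl in place of chlorophenyl on the shared core

The source may hold more compounds than are shown below. What is called first, only, known or untested is meant among the compounds shown, and "the series" means these compounds.

Measured so far in an in vitro functional assay on HEK285-7 cells for antagonist activity at prostaglandin D2 receptor 2 (Homo sapiens), read by BRET and beta-arrestin recruitment; a lower number here means a stronger inhibitor, a higher number a weaker inhibitor:
compound 1 `O=C(O)Cc1sc(C2COc3ccccc3O2)nc1-c1ccc(Cl)cc1` gives 2000 nM
compound 2 `O=C(O)Cc1sc(C(c2ccc(F)cc2)c2ccc(F)cc2)nc1-c1ccc(Cl)cc1` gives 180 nM
compound 3 `COc1ccc(C(c2ccccn2)c2nc(-c3ccc(Cl)cc3)c(CC(=O)O)s2)cc1` gives 310 nM

Compound 2 has the lowest of the three numbers. Compound 3 sits within the usual scatter of compound 2, so no order between those two is claimed; compound 1 sits well beyond it. Compound 4 `Cc1cc(-c2nc(C(c3ccc(F)cc3)c3ccc(F)cc3)sc2CC(=O)O)ccn1` is not yet measured. It differs from compound 2 in one place: 2-methylpyridin-4-yl in place of 4-chlorophenyl on an aromatic carbon. Among the compounds with values here, no measured pair in this set carries the same change, so the direction rests on the change alone. A modest weakening is expected, a 2.2-fold higher number from compound 2 to compound 4 (0.35 log units; beyond the scatter), with wide allowance on both sides. For compound 4 the estimate in this assay is 400 nM, between 130 nM and 1300 nM.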

Compound 4, half-maximal inhibitory concentration: 53 nM
Compound 4: middle estimate off by 7.5-fold (0.88 log units), on the high side, and the stated range ends above it.
By their numbers in this assay, from the lowest: compound 4; then compounds 2 and 3 (each within the scatter of the next); then compound 1.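

This position, on the aromatic carbon next to the ring nitrogen, tolerates more than 4-chlorophenyl. In this assay, 2-methylpyridin-4-yl in its place gives a 3.4-fold lower number from compound 2 to compound 4 (0.53 log units; beyond the scatter), with the rest of compound 2 unchanged. No measurement shown here explains this step.

The compounds shown leave open whether the ring nitrogen or the methyl carries the step, a question that pyridin-4-yl and 4-methylphenyl at this position would address. Also open, on these data alone, is whether the same change holds with the other large groups on the shared core.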